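The compounds below may be only part of what the source reports. "The series", "measured", "known", "first", "only" and "open" are said of these compounds alone.

Compound 3 `O=C1NCCN1c1ccc(S(=O)(=O)Nc2ccc(Br)cc2)cc1` gives 130 nM in a functional assay on M21 cells (Homo sapiens) for antiproliferative activity, read by sulforhodamine B assay, with a stated time of 48 h (a lower number here means a stronger inhibitor, a higher number a weaker inhibitor), the highest of the three numbers recorded so far. Compound 1 `Cc1ccc(NS(=O)(=O)c2ccc(N3CCNC3=O)cc2)cc1C` gives 94 nM and compound 2 `CCc1cccc(NS(=O)(=O)c2ccc(N3CCNC3=O)cc2)c1` gives 82 nM; the steps of a 1.4-fold higher number from compound 1 to compound 3 (0.14 log units; within the scatter) and a 1.6-fold higher number from compound 2 to compound 3 (0.20 log units; within the scatter) both stay within the scatter, as does a 1.1-fold lower number from compound 1 to compound 2 (0.06 log units; within the scatter), so the three aryl groups on the sulfonamide nitrogen have so far been indistinguishable. Compound 4 `COc1cccc(NS(=O)(=O)c2ccc(N3CCNC3=O)cc2)c1` introduces another change at the same place: 3-methoxyphenyl in place of 4-bromophenyl on a sulfonamide nitrogen. Every measured step at this position was within the scatter, so no step beyond the scatter is expected in this assay. The step is estimated as a 1.3-fold lower number from compound 3 to compound 4 (0.11 log units; within the scatter). For compound 4 the expected value is 100 nM, in the range 45 nM to 220 nM.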

Compound 4, half-maximal inhibitory concentration: 65 nM
Compound 4: the middle estimate sits 1.5-fold (0.19 log units) above what was measured; low and high end bracket the measured number.
By their numbers in this assay, from the lowest: compounds 4, 2, 1 and 3 (each within the scatter of the next).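

In this assay, for the compounds shown here, the 3-methoxyphenyl group, the only aryl group here with an oxygen and a hydrogen-bond acceptor, does not separate from the others on the sulfonamide nitrogen. The step of a 2.0-fold lower number from compound 3 to compound 4 (0.30 log units; within the scatter) is the largest yet at this position but stays within the scatter, as do the steps of a 1.3-fold lower number from compound 2 to compound 4 (0.10 log units; within the scatter) and of a 1.4-fold lower number from compound 1 to compound 4 (0.16 log units; within the scatter) in this series. Nothing at hand explains this sameness.

The compounds shown leave open whether an amine or a carboxylic acid on this aromatic ring, or a longer chain in place of the aryl group, would give a step beyond the scatter.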